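Methoxy for fluoro on the sulfanylphenyl of compound 1

This account rests on a few compounds, and the source may have more. Where it says the series, first, only, none or still open, it means among the compounds named here.

Compound 1 `Nc1cc(N)c2nc(-c3ccccc3)c(Sc3ccc(F)cc3)nc2c1` is the reference point of the series. In a functional assay on SK-OV-3 cells (Homo sapiens) for inhibition, read by sulforhodamine B assay, with a stated time of 48 h (on this read-out higher numbers stand for lower toxicity in this test and lower numbers for higher toxicity in this test), compound 1 gives 63100 nM, the highest of the two numbers available. Compound 2 `COc1cc(CNc2nc3cc(N)cc(N)c3nc2-c2ccccc2)cc(OC)c1OC` gives in this assay 36300 nM; the gap to compound 1 lies within the usual scatter, so the two numbers cannot be put in order. Compound 3 `CCOC(=O)[C@H](CCC(=O)O)NC(=O)c1ccc(CNc2nc3cc(N)cc(N)c3nc2-c2ccccc2)cc1` returns only a limit in this assay, < 100000 nM, not a number (the limit of < 100000 nM in this assay, at which 1 of the 3 values shown sits). Within the data shown here, no pair of measured compounds differs at a single site, so no measured step exists against which to calibrate the change under study.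

Compound 4 `COc1ccc(Sc2nc3cc(N)cc(N)c3nc2-c2ccccc2)cc1` differs from compound 1 by methoxy in place of fluoro on an aromatic carbon. The measured numbers give no guide to the effect of this change in this assay; with compound 1 and compound 2 close together and compound 3 at a limit, a step of no more than the scatter, in either direction, is expected. For compound 4 the expected step of a 1.1-fold lower number from compound 1 to compound 4 (0.06 log units; within the scatter) stays within that scatter. Compound 4 is estimated at 55000 nM in this assay, between 20000 nM and 150000 nM, with a fair chance that only a limit is reported.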

Compound 4, concentration lethal to 50% of the cells: < 100000 nM
Compound 4: a limit, no number; the forecaster's own chance of this, stated with the estimate: 30%; the middle value does not contradict the limit.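

Compound 4 returns only a limit, < 100000 nM, in this assay, so no step from compound 1 to compound 4 can be read: the limit of < 100000 nM in this assay, at which 2 of the 4 values shown sit.

The compounds shown leave open whether methoxy in place of fluoro on an aromatic carbon shifts the number in this assay at all, and in which direction.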